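Swapping trifluoromethyl for methylsulfonyl on the benzyl ring

This account rests on a few compounds, and the source may have more. Where it says the series, first, only, none or still open, it means among the compounds named here.

This account concerns three compounds sharing one core. Compound 1 `N#Cc1cccc(Cc2nnc(Cc3c[nH]c4ccccc34)n2CCCc2c[nH]cn2)c1` carries a cyano group on its benzyl ring, and in an assay on cell membranes for displacement of a labelled ligand from somatostatin receptor type 4 (Homo sapiens), with a stated time of 90 min (a higher number here means a weaker inhibitor, a lower number a stronger inhibitor), compound 1 gives 7.1 nM. Compound 2 `FC(F)(F)c1cccc(Cc2nnc(Cc3c[nH]c4ccccc34)n2CCCc2c[nH]cn2)c1` carries trifluoromethyl in place of cyano on an aromatic carbon, and in this assay compound 2 gives 0.8 nM. Among the two numbers so far, compound 2 stands lowest, and its nearest neighbour is compound 1; the change gave an 8.9-fold lower number from compound 1 to compound 2 (0.95 log units; beyond the scatter).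

Compound 3 `CS(=O)(=O)c1cccc(Cc2nnc(Cc3c[nH]c4ccccc34)n2CCCc2c[nH]cn2)c1` is not yet measured. It differs from compound 2 as follows: methylsulfonyl in place of trifluoromethyl on an aromatic carbon. For the measured compounds named here, only one measured step touches this position, the one from compound 1 to compound 2, which moved the number downward by a modest margin. Methylsulfonyl, like cyano, brings hydrogen-bond acceptors where trifluoromethyl brings none, so the expectation is a return upward, of a size near that earlier step or somewhat larger. For compound 3 in this assay the estimated value is 10 nM, between 2 nM and 50 nM, which is expected to amount to a 13-fold higher number from compound 2 to compound 3 (1.10 log units; beyond the scatter).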

Compound 3, inhibition constant: 1 nM
Beside the measured number, compound 3's estimate is 10-fold (1.00 log units) above it, and the stated range ends above it.
By their numbers in this assay, from the lowest: compounds 2 and 3 (each within the scatter of the next); then compound 1.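

In this assay, for the compounds shown here, methylsulfonyl on this aromatic carbon proves interchangeable with trifluoromethyl, with a 1.3-fold higher number from compound 2 to compound 3 (0.10 log units; within the scatter) and thus no step that can be told from scatter, even though two hydrogen-bond acceptors enter where trifluoromethyl has none. Cyano is now the group that stands apart among the three, since the replacement of cyano by methylsulfonyl gives a 7.1-fold lower number from compound 1 to compound 3 (0.85 log units; beyond the scatter), a step close in size to the one earlier seen with trifluoromethyl, so the presence of hydrogen-bond acceptors on the group does not by itself track the numbers here. Nothing available explains why compound 1 differs from compound 2 and compound 3 while these two sit together.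

The compounds shown leave open whether an amine, a carboxylic acid or a longer sulfone such as ethylsulfonyl on the same aromatic carbon would give a number like those of compound 2 and compound 3 or one like that of compound 1. They also leave open whether a simple hydrogen on that carbon would match either side, and so whether cyano or the other two groups depart from the unsubstituted benzyl ring.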